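Thiophene Arm Replaces Chlorophenyl: Expectation for Compound 4

The source may hold more compounds than are shown below. What is called first, only, known or untested is meant among the compounds shown, and "the series" means these compounds.

Compound 1 `CC1=CC[C@H](C(C)(C)NC(=S)N/N=C/c2ccc(O)cc2)CC1` — in a functional assay on K562 cells (Homo sapiens) for inhibition, read by sulforhodamine B assay, with a stated time of 48 h (on this read-out lower numbers stand for stronger inhibition of growth and higher numbers for weaker inhibition of growth), compound 1 gives > 100000 nM, which is a limit of the assay.
Compound 2 `CC1=CC[C@H](C(C)(C)NC(=S)N/N=C/c2ccccc2Cl)CC1` — in this assay compound 2 gives 66200 nM.
Compound 3 `CC1=CC[C@H](C(C)(C)NC(=S)N/N=C/c2ccc(Cl)cc2)CC1` — in this assay compound 3 gives 16900 nM.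

Compound 3 gives the lowest of the two numbers reported; compound 2 is nearest, and the step of a 3.9-fold lower number from compound 2 to compound 3 (0.59 log units; beyond the scatter) lies beyond the scatter. The third value, that of compound 1, sits at the limit (the limit of > 100000 nM in this assay, at which 1 of the 3 values shown sits). The steps of an at least 1.5-fold lower number from compound 1 to compound 2 (0.17 log units; that floor lies within the scatter) and an at least 5.9-fold lower number from compound 1 to compound 3 (0.77 log units; beyond the scatter) complete the measured picture.

Compound 4 `CC1=CC[C@H](C(C)(C)NC(=S)N/N=C/c2cccs2)CC1` has not yet been measured. It differs from compound 3 by thiophen-2-yl in place of 4-chlorophenyl on a carbon with a double bond to nitrogen. Within the data shown here, no measured step swaps one aromatic ring for another of a different size; the three measured steps alter only the substituent on the six-membered ring or its placement, and they show the number is sensitive to that part of the molecule. The chloro substituent, which compound 3 carries and compound 1 lacks, departs together with the ring. The estimated step is a 2.4-fold higher number from compound 3 to compound 4 (0.37 log units; beyond the scatter), a rise in the number beyond the scatter. Compound 4 is therefore expected to give 40000 nM in this assay, within a range from 12000 nM to 130000 nM.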

Compound 4, concentration for total growth inhibition: > 100000 nM
Compound 4 was reported as a limit (the forecaster's own chance of this, stated with the estimate: 25%); middle value at least 2.5-fold (0.39 log units) from the limit.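

The earlier steps shown here changed only the substituent on a six-membered ring, whereas this change replaces the ring itself on the carbon with a double bond to nitrogen. Thiophen-2-yl in place of 4-chlorophenyl gives an at least 5.9-fold higher number from compound 3 to compound 4 (0.77 log units; beyond the scatter) and so shows that the number also responds to the ring that carries the arm, and that a five-membered aromatic ring with a sulfur atom does not keep the level of compound 3. Against the other chlorinated arm, the exchange gives an at least 1.5-fold higher number from compound 2 to compound 4 (0.17 log units; that floor lies within the scatter) and that floor lies within the scatter, so thiophen-2-yl and 2-chlorophenyl cannot be put in order. In this assay compound 4 gives > 100000 nM which is a limit of the assay and not a number, and the step between compound 1 and compound 4 cannot be read: the limit of > 100000 nM in this assay, at which 2 of the 4 values shown sit.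

The compounds shown leave open whether the loss follows the change of ring or the departure of the chlorine, since no thiophene arm carrying a chloro group stands among them. They also leave open how a pyridine ring, or a phenyl ring carrying a methoxy or trifluoromethyl group, would read on the same carbon.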